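A few compounds are considered here, and "the series" means these few. Any claim that something is new, unique, unknown or untested is made for them only; others in the source may bear on it.

Compound 1 `CC(C(=O)NCc1ccc(C(F)(F)F)nc1NC1CCCCC1)c1ccc(NS(C)(=O)=O)c(F)c1` and compound 2 `CC(C(=O)NCc1ccc(C(F)(F)F)nc1Nc1ccc(F)cc1)c1ccc(NS(C)(=O)=O)c(F)c1` share one core and differ only at a nitrogen on an aromatic ring. In a functional assay on CHO-K1 cells for antagonist activity at transient receptor potential cation channel subfamily V member 1 (Homo sapiens), read by FLIPR (on this read-out lower numbers stand for stronger inhibition and higher numbers for weaker inhibition), compound 1 gives 20.4 nM, and compound 2 gives 39.2 nM. The step of a 1.9-fold higher number from compound 1 to compound 2 (0.28 log units; within the scatter) is small, so on the two numbers shown compound 2 and compound 1 cannot be told apart. Compound 3 `Cc1ccc(Nc2nc(C(F)(F)F)ccc2CNC(=O)C(C)c2ccc(NS(C)(=O)=O)c(F)c2)cc1C` alters the same place: 3,4-dimethylphenyl in place of 4-fluorophenyl on a nitrogen on an aromatic ring. For the measured compounds named here, only the step from compound 1 to compound 2 bears on this, and it stayed within the scatter, so no step beyond the scatter is expected in this assay. Compound 3 is therefore estimated at 35 nM, with a likely range from 12 nM to 110 nM. The expected step is a 1.1-fold lower number from compound 2 to compound 3 (0.05 log units; within the scatter).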

Compound 3, inhibition constant: 39.3 nM
Beside the measured number, compound 3's estimate is 1.1-fold (0.05 log units) below it; the range from low to high includes it.
By their numbers in this assay, from the lowest: compounds 1, 2 and 3 (each within the scatter of the next).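

In this assay, the number shows a 1.0-fold higher number from compound 2 to compound 3 (0.00 log units; within the scatter) when 3,4-dimethylphenyl replaces 4-fluorophenyl, and a 1.9-fold higher number from compound 1 to compound 3 (0.28 log units; within the scatter) when it replaces cyclohexyl. This nitrogen has now carried cyclohexyl and two differently substituted phenyl groups, and the three compounds cannot be told apart on these numbers. No measurement shown explains why they read alike. Still open, from the compounds shown here alone, is whether a much smaller group on this nitrogen, such as methyl, would read the same. A phenyl group bearing an amine or a carboxylic acid also remains untested among the compounds shown here.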